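Solubility of a succinimide analogue estimated from two amines

The source may report more compounds than this note shows. Statements on the series, on what has been measured and on what is new or still open speak of the compounds shown alone.

Measured in a physicochemical assay for solubility, read by HPLC, with a stated time of 24 h (on this read-out higher numbers stand for higher solubility and lower numbers for lower solubility), so far:
compound 1, `CN(CCC#N)C[C@H]1CN(c2ccc(-n3cc(-c4ccccn4)cn3)c(F)c2)C(=O)O1`, 64500 nM
compound 2, `CCN1CCN(C[C@H]2CN(c3ccc(-n4cc(-c5ccccn5)cn4)c(F)c3)C(=O)O2)CC1`, 706000 nM
compound 3, `O=C1O[C@@H](CN2CCC(c3ccc(F)cc3)CC2)CN1c1ccc(-n2cc(-c3ccccn3)cn2)c(F)c1`, <= 19400 nM

Compound 3 gives only a limit in this assay, (the limit of <= 19400 nM in this assay, at which 1 of the 3 values shown sits), and not a number. Among the two numbers, compound 2 stands highest: the step of an 11-fold higher number from compound 1 to compound 2 (1.04 log units; beyond the scatter) is the only measured step, and it is large.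

Compound 4, `O=C1CCC(=O)N1C[C@H]1CN(c2ccc(-n3cc(-c4ccccn4)cn3)c(F)c2)C(=O)O1`, has not yet been measured. It differs from compound 2 by 2,5-dioxopyrrolidin-1-yl in place of 4-ethylpiperazin-1-yl on a saturated chain carbon bound to a saturated ring carbon. The group that leaves is the one whose arrival in the measured step raised the number so much, and the group that enters is neither of the groups seen in compound 1 or compound 3. Among the measured compounds shown here, the measured step bears on the change only in that it shows the 4-ethylpiperazin-1-yl group going with the highest number; no measured step tells what a 2,5-dioxopyrrolidin-1-yl group does here.

Compound 4 is therefore expected to fall well below compound 2, and the expected step is a 35-fold lower number from compound 2 to compound 4 (1.55 log units; beyond the scatter). For compound 4 the estimate in this assay is 20000 nM, with a range from 5000 nM to 80000 nM, and a real chance that only a limit is reported.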

Compound 4, solubility: 45300 nM
The estimate for compound 4 lay 2.3-fold (0.36 log units) below the measured number; the measured number falls inside the stated range.
By their numbers in this assay, from the lowest: compounds 4 and 1 (each within the scatter of the next); then compound 2. At a limit, below all of these: compound 3.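

In this assay, the change on a saturated chain carbon bound to a saturated ring carbon now has a second measured step out of compound 2: the entry of 2,5-dioxopyrrolidin-1-yl in place of 4-ethylpiperazin-1-yl gives a 16-fold lower number from compound 2 to compound 4 (1.19 log units; beyond the scatter) and so shows that a group new to the series also ends far from compound 2. The other step, a 1.4-fold lower number from compound 1 to compound 4 (0.15 log units; within the scatter), places two quite different groups, 2,5-dioxopyrrolidin-1-yl and (2-cyanoethyl)(methyl)amino, within the scatter of each other, which leaves compound 2 alone among the three numbers while the two others cannot be told apart. Among the compounds shown here, nothing measured here gives a cause for either step, and the only supporting information on record, a limit for another compound, does not bear on this result.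

From the compounds shown here alone, it remains open whether a piperazine without the ethyl group or a morpholine in this place would stand with compound 2 or with compounds 1 and 4. Also open, going by these compounds, is what an open-chain acetamide or a carboxylic acid on the same carbon would give, set against the 2,5-dioxopyrrolidin-1-yl ring of compound 4.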